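Swapping the amide for a pyrimidine amine on the shared core

A few compounds are considered here, and "the series" means these few. Any claim that something is new, unique, unknown or untested is made for them only; others in the source may bear on it.

Of the compounds shown here, three built on the shared core have been measured in a functional assay on LNCaP cells (Homo sapiens) for antiproliferative activity, read by CCK-8 assay, with a stated time of 6 days; a higher number here means a weaker inhibitor, a lower number a stronger inhibitor. Compound 1 `CC(=O)c1cc(C(=O)N[C@H](C)Cn2ccc(-c3cc(F)c(C#N)c(Cl)c3)n2)n[nH]1` gives 1080 nM. Compound 2 `COc1ccc(C(=O)N[C@@H](C)Cn2ccc(-c3ccc(C#N)c(Cl)c3)n2)cc1` gives 3410 nM. Compound 3 `C[C@@H](Cn1ccc(-c2ccc(C#N)c(Cl)c2)n1)NC(=O)c1ccccc1F` gives 1810 nM. The number of compound 3 sits among those of compound 1 and compound 2, and its gap to each of them is within the scatter, so nothing separates the three on this assay.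

Among the measured compounds shown here, the one step between measured compounds is a 1.9-fold lower number from compound 2 to compound 3 (0.28 log units; within the scatter), which changes only the aryl group on the carbonyl carbon and stays within the scatter.

Compound 4 `C[C@@H](Cn1ccc(-c2ccc(C#N)c(Cl)c2)n1)Nc1cncnc1` differs from compound 3 by pyrimidin-5-yl in place of (2-fluorophenyl)carbonyl on an amine nitrogen. This removes the carbonyl altogether and places an aromatic ring with two heteroatoms directly on the amine nitrogen. For the measured compounds named here, no measured step touches that part of the molecule; the step from compound 2 to compound 3 varies the aryl group while keeping the carbonyl, so it offers only a loose guide. Given that, compound 4 is expected to change by about a 1.4-fold higher number from compound 3 to compound 4 (0.14 log units; within the scatter), with a wide range on either side. The estimate for compound 4 is 2500 nM, expected to lie between 800 nM and 8000 nM.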

Compound 4, half-maximal inhibitory concentration: 2070 nM
The estimate for compound 4 lay 1.2-fold (0.08 log units) above the measured number; measured number inside the range.
By their numbers in this assay, from the lowest: compounds 1, 3, 4 and 2 (each within the scatter of the next, the first and the last beyond it).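

In this assay, the change from (2-fluorophenyl)carbonyl to pyrimidin-5-yl on the amine nitrogen gives a 1.1-fold higher number from compound 3 to compound 4 (0.06 log units; within the scatter), so this assay does not separate the two compounds. The earlier step kept the carbonyl and varied only the aryl group, whereas this one shows that the number stays within the scatter even when the carbonyl is gone and an aromatic ring with two hetero atoms sits directly on the amine nitrogen. Nothing available here accounts for this result.

Going by these compounds, every step read so far lies within the scatter, so it remains open whether any group on this amine nitrogen can move the number beyond it. A pyridin-3-yl or a plain phenyl directly on that nitrogen, a methyl on the same nitrogen of compound 4, or a saturated ring such as a piperidine in place of the pyrimidin-5-yl would each put that question to a further test.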